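The source may hold more compounds than are shown below. What is called first, only, known or untested is meant among the compounds shown, and "the series" means these compounds.

Measured so far:
- compound 1, `COc1nc(N)nc2c1c(-c1ccsc1)cn2[C@@H]1O[C@H](CO)[C@@H](O)[C@H]1O`. In a functional assay on A549 cells (Homo sapiens), read by MTT assay, with a stated time of 72 h (on this read-out higher numbers stand for weaker inhibition and lower numbers for stronger inhibition), compound 1 gives > 100000 nM, a limit of the assay.
- compound 2, `COc1nc(N)nc2c1c(-c1cccs1)cn2[C@@H]1O[C@H](CO)[C@@H](O)[C@H]1O`. In this assay compound 2 gives > 20000 nM, a limit of the assay.
- compound 3, `CNc1ncnc2c1c(-c1cccs1)cn2[C@@H]1O[C@H](CO)[C@@H](O)[C@H]1O`. In this assay compound 3 gives > 20000 nM, a limit of the assay.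

Within the data shown here, the only matched pair is compound 2 against compound 1, the change (thiophen-3-yl in place of thiophen-2-yl on an aromatic carbon). Its step is a step that the two limits leave unreadable from compound 2 to compound 1, so the direction of this change cannot be read: one value sits at the limit of > 20000 nM in this assay, at which 2 of the 3 values shown sit, and the other at the limit of > 100000 nM in this assay, at which 1 of the 3 values shown sits. The difference between the core of compound 2 and the core of compound 3 is not broken down here.

Compound 4, `CNc1ncnc2c1c(-c1ccsc1)cn2[C@@H]1O[C@H](CO)[C@@H](O)[C@H]1O`, has not been measured in this assay. It arises from compound 3 by thiophen-3-yl in place of thiophen-2-yl on an aromatic carbon, the same change as that from compound 2 to compound 1, at the same place. Because compound 3 stands at > 20000 nM and the measured instance of this change is a step that the two limits leave unreadable from compound 2 to compound 1, only a weak expectation is possible. The step from compound 3 to compound 4 is expected near a step that the limit leaves unreadable from compound 3 to compound 4. For compound 4 the estimate is 40000 nM, within 15000 nM to 150000 nM, most likely again reported as a limit.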

Compound 4, half-maximal inhibitory concentration: > 20000 nM
Compound 4: no number, only a limit; the forecaster's own chance of this, stated with the estimate: 85%; the middle value lies beyond the limit too.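

No new step can be read: compound 3 and compound 4 both stand at a limit in this assay, so the exchange of thiophen-2-yl for thiophen-3-yl stays unreadable on this core as well. The compounds shown leave open whether thiophen-2-yl and thiophen-3-yl differ on either core, and whether any compound here has a measurable half-maximal inhibitory concentration in this assay.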